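Nitro to methoxy on the pendant phenyl ring

The source may hold more compounds than are shown below. What is called first, only, known or untested is meant among the compounds shown, and "the series" means these compounds.

Measured so far in a functional assay on SK-MEL-2 cells (Homo sapiens) for cytotoxicity, read by sulforhodamine B assay, with a stated time of 2 days, tested at 100 uM; on this read-out higher numbers stand for more inhibition at the one concentration tested (going by the name of the read-out) and lower numbers for less inhibition:
compound 1 `CCCc1n[nH]c2c(=O)n(NC(=O)c3ccccc3)c(-c3cccc([N+](=O)[O-])c3)nc12`: 22.9%
compound 2 `CCCc1n[nH]c2c(=O)n(NC(=O)c3ccccc3)c(-c3cccc(OC)c3)nc12`: 16.7%
compound 3 `O=C(Nn1c(-c2cccc([N+](=O)[O-])c2)nc2c(-c3ccco3)n[nH]c2c1=O)c1ccccc1`: 23%

The change methoxy in place of nitro on an aromatic carbon gave the step of a number 6.2 percentage points lower from compound 1 to compound 2 (within the scatter). The core of compound 3 differs from the core of compound 1 by furan-2-yl in place of propyl on an aromatic carbon, which gave the step of a number 0.1 percentage points higher from compound 1 to compound 3 (within the scatter). Compound 4 `COc1cccc(-c2nc3c(-c4ccco4)n[nH]c3c(=O)n2NC(=O)c2ccccc2)c1` has not yet been measured in this assay. It differs from compound 3 by methoxy in place of nitro on an aromatic carbon; this is the same change as that from compound 1 to compound 2, at the same place in the same words. The step of a number 6 percentage points lower from compound 3 to compound 4 (within the scatter) is expected for compound 4, resting on the step of a number 6.2 percentage points lower from compound 1 to compound 2 (within the scatter) seen once. Compound 4 is estimated at 17%, with the range 8% to 28%.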

Compound 4, a percentage reported as inhibition, at one concentration (the size of the read-out at that concentration, not a potency): 43.2%
Compound 4: middle estimate off by 26.2 percentage points, on the low side, and the stated range ends below it.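

In this assay, 3-nitrophenyl to 3-methoxyphenyl did not carry over between the two cores, giving a number 20.2 percentage points higher from compound 3 to compound 4 (beyond the scatter) with furan-2-yl in place of propyl: the same change on two cores in this assay, a number 6.2 percentage points lower (within the scatter) from compound 1 to compound 2 and a number 20.2 percentage points higher (beyond the scatter) from compound 3 to compound 4, 26.4 percentage points apart, beyond the scatter of two such steps

Read the other way, furan-2-yl in place of propyl gave a number 26.5 percentage points higher from compound 2 to compound 4 (beyond the scatter) with the methoxy group present, so this change also did not carry over: the same change on two cores in this assay, a number 0.1 percentage points higher (within the scatter) from compound 1 to compound 3 and a number 26.5 percentage points higher (beyond the scatter) from compound 2 to compound 4, 26.4 percentage points apart, beyond the scatter of two such steps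

The two changes therefore do not add across these four compounds, but this rests on a single set of four compounds at one concentration and does not show the cause or how either change behaves on another core.

Still open, as far as these compounds go, is whether an amine on the phenyl ring would follow methoxy or nitro when furan-2-yl is present. Also open, from the compounds shown here alone, is whether a longer chain in place of propyl would change the methoxy step.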